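Aryl swap at the saturated ring carbon

The compounds below may be only part of what the source reports. "The series", "measured", "known", "first", "only" and "open" are said of these compounds alone.

For the measured compounds named here, compound 2 `COc1cc(N2C(N)=C(C#N)C(c3ccccc3Cl)C3=C2CC(C)(C)CC3=O)cc(OC)c1OC` stands lowest of the two numbers so far: in a functional assay on Ehrlich cells (Mus musculus) for cytotoxicity, tested at 25 ug/mL (on this read-out lower numbers stand for a weaker effect and higher numbers for a stronger effect at the one concentration tested), compound 2 gives 15%, whereas compound 1 `COc1cc(N2C(N)=C(C#N)C(/C=C/c3ccccc3)C3=C2CC(C)(C)CC3=O)cc(OC)c1OC` gives 30%. Going by the values given here, the only measured step at this position, a number 15 percentage points lower from compound 1 to compound 2 (beyond the scatter), bears on the change but is a different swap. Compound 3 `COc1cc(N2C(N)=C(C#N)C(c3ccc(C)o3)C3=C2CC(C)(C)CC3=O)cc(OC)c1OC` carries 5-methylfuran-2-yl in place of 2-chlorophenyl on a saturated ring carbon. Among the compounds with values here, no measured step tests a five-membered aromatic ring with one hetero atom here, so the expectation rests loosely on that single step and on the wide scatter. Compound 3 is expected at 20%, within a range of 5% to 40%, which means an expected step of a number 5 percentage points higher from compound 2 to compound 3 (within the scatter) of no clear direction beyond the scatter.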

Compound 3, a percentage reported as activity, at one concentration (the size of the read-out at that concentration, not a potency): 31%
Estimate against measurement, compound 3: 11 percentage points below; the measured number falls inside the stated range.
By their numbers in this assay, from the lowest: compound 2; then compounds 1 and 3 (each within the scatter of the next).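

In this assay, 5-methylfuran-2-yl in place of 2-chlorophenyl on the saturated ring carbon gives a number 16 percentage points higher from compound 2 to compound 3 (beyond the scatter) and shows that the low number of compound 2 is not general to cyclic groups at this position. Replacing 2-phenylethenyl with 5-methylfuran-2-yl gives a number 1 percentage points higher from compound 1 to compound 3 (within the scatter) and leaves these two groups indistinguishable here. No available measurement accounts for these steps.

Going by these compounds, whether the step from 2-chlorophenyl follows the ring, the chlorine or the methyl remains open. A plain phenyl, or furan-2-yl without the methyl, would help separate these changes.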